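The source may report more compounds than this note shows. Statements on the series, on what has been measured and on what is new or still open speak of the compounds shown alone.

Measured so far in a functional assay on MCF7 cells (Homo sapiens) for inhibition, read by MTT assay, with a stated time of 72 h; on this read-out higher numbers stand for weaker inhibition and lower numbers for stronger inhibition:
- Compound 1 `CCc1ccc(NC(=O)C2CCN(C/C=C/c3ccccc3)CC2)cc1`: 20000 nM
- Compound 2 `CCCc1ccc(NC(=O)C2CCN(C/C=C/c3ccccc3)CC2)cc1`: 9030 nM
- Compound 3 `CC(C)c1ccc(NC(=O)C2CCN(C/C=C/c3ccccc3)CC2)cc1`: 9100 nM

These three differ only in the alkyl group on the aromatic ring: ethyl, propyl and isopropyl. Compound 3 cannot be told apart from its propyl partner, as the data show a 1.0-fold higher number from compound 2 to compound 3 (0.00 log units; within the scatter). Against the ethyl member, they show a 2.2-fold lower number from compound 1 to compound 3 (0.34 log units; beyond the scatter). Its propyl partner behaves alike, with a 2.2-fold lower number from compound 1 to compound 2 (0.35 log units; beyond the scatter).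

Compound 4 `COc1ccccc1NC(=O)C1CCN(C/C=C/c2ccccc2)CC1` keeps the shared core but carries 2-methoxyphenyl in place of 4-isopropylphenyl on an amide-type nitrogen. Going by the values given here, no measured step introduces a methoxy group or moves a group around the ring, so the evidence is only indirect. The two modest steps link the ethyl compound to the larger alkyl groups, and compound 4 carries neither propyl nor isopropyl. The closest guide is therefore compound 1 at 20000 nM, although it is far from a true match.

A modest rise in this assay is expected, with the estimated change being a 2.0-fold higher number from compound 3 to compound 4 (0.30 log units; within the scatter). For compound 4 the estimate is 18000 nM, with an expected range of 7000 nM to 45000 nM.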

Compound 4, half-maximal inhibitory concentration: > 100000 nM
Compound 4: a limit, no number; the forecaster's own chance of this, stated with the estimate: 15%; middle value at least 5.5-fold (0.74 log units) from the limit.
By their numbers in this assay, from the lowest: compounds 2 and 3 (each within the scatter of the next); then compound 1. At a limit, above all of these: compound 4.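

In this assay, compound 4 sits at a limit and not at a number: the limit of > 100000 nM in this assay, at which 1 of the 4 values shown sits. The alkyl swaps among compounds 1, 2 and 3 gave modest steps at most, whereas replacing the whole group on the amide-type nitrogen with 2-methoxyphenyl gives large ones, with an at least 10-fold higher number from compound 3 to compound 4 (1.04 log units; beyond the scatter) and an at least 11-fold higher number from compound 2 to compound 4 (1.04 log units; beyond the scatter). Even against the ethyl member there is an at least 5.0-fold higher number from compound 1 to compound 4 (0.69 log units; beyond the scatter), so the group at this place can move the read-out much further than changing the alkyl group alone did, and all three steps are minimum sizes.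

This single change removes the alkyl group and brings in a methoxy group at the same time, so the compounds shown cannot tell which of the two matters, or whether the place of the methoxy group on the ring plays a part. On these data alone, it also stays open how a plain phenyl group on the amide-type nitrogen would read here, and whether a longer chain such as butyl would continue the trend from ethyl to propyl.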